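The source may report more compounds than this note shows. Statements on the series, on what has been measured and on what is new or still open speak of the compounds shown alone.

Working notes on the series. In an assay on isolated protein for inhibition of DNA topoisomerase 1 (Homo sapiens), with a stated time of 30 min, tested at 20 uM (a lower number here means a weaker effect, a higher number a stronger effect of the compound at the concentration tested), compound 1 `Cc1ccc2c(=O)[nH]c(-c3ccccc3C)nc2c1` gives 39.2% and compound 2 `Cc1ccc2c(=O)[nH]c(-c3ccccc3OC(F)(F)F)nc2c1` gives 100%. Among the compounds with values here, compound 2 stands highest of the two numbers so far; the nearest is compound 1, and the step of a number 60.8 percentage points higher from compound 1 to compound 2 (beyond the scatter) is beyond the scatter. Compound 3 `Cc1ccc2c(=O)[nH]c(-c3ccccc3F)nc2c1` has not yet been measured. It differs from compound 2 in one place: fluoro in place of trifluoromethoxy on an aromatic carbon. Within the data shown here, only one measured step touches this position, the exchange of methyl for trifluoromethoxy from compound 1 to compound 2, which was large and upward. Fluoro is a single heavy atom, closer in count to the methyl of compound 1 than to the trifluoromethoxy of compound 2, so a step downward from compound 2 is expected in this assay, of a size between no change and the full reversal seen in a number 60.8 percentage points higher from compound 1 to compound 2 (beyond the scatter). Compound 3 is therefore estimated at 60% with a range of 30% to 95%, meaning an expected step of a number 40 percentage points lower from compound 2 to compound 3 (beyond the scatter).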

Compound 3, a percentage reported as inhibition, at one concentration (the size of the read-out at that concentration, not a potency): 0%
The estimate for compound 3 lay 60 percentage points above the measured number, outside the stated range (below it).
By their numbers in this assay, from the lowest: compound 3; then compound 1; then compound 2.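

In this assay this position now moves the reading in both directions from methyl: a number 100 percentage points lower from compound 2 to compound 3 (beyond the scatter), and a number 39.2 percentage points lower from compound 1 to compound 3 (beyond the scatter). Methyl therefore does not mark the low end of the series, and fluoro sits below it. With two small groups separated by a step beyond the scatter, the contrast between a large and a small group does not by itself describe this position across compounds 1, 2 and 3. Nothing available explains these differences.

The compounds shown leave open whether the high reading of compound 2 follows the oxygen or the fluorines of trifluoromethoxy, a question that methoxy and trifluoromethyl at this place would separate. On these data alone, how an amine or a carboxylic acid would read here also stays open.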